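Swapping the Halogenated Benzyl Group on a Shared Core

A few compounds are considered here, and "the series" means these few. Any claim that something is new, unique, unknown or untested is made for them only; others in the source may bear on it.

Compound 1 `Cc1cc(N2CC[C@@H](C)[C@@H](N(C)c3ncnc4[nH]ccc34)C2)n2nc(SCC3CC3)nc2n1` gives 27900 nM in a toxicity assay on GES1 cells (Homo sapiens) for inhibition, read by MTT assay, with a stated time of 72 h; on this read-out higher numbers stand for weaker inhibition and lower numbers for stronger inhibition. Compound 2 `C=CCSc1nc2nc(C)cc(N3CC[C@@H](C)[C@@H](N(C)c4ncnc5[nH]ccc45)C3)n2n1` reaches only the limit of this assay, > 100000 nM. Compound 3 `Cc1cc(N2CC[C@@H](C)[C@@H](N(C)c3ncnc4[nH]ccc34)C2)n2nc(SCc3ccccc3Br)nc2n1` likewise sits at the limit, > 100000 nM.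

Compound 3 thus stands at the weak end of what this assay shows, where it reports a limit and no number (the limit of > 100000 nM in this assay, at which 2 of the 3 values shown sit). Compound 4 `Cc1cc(N2CC[C@@H](C)[C@@H](N(C)c3ncnc4[nH]ccc34)C2)n2nc(SCc3ccc(Cl)cc3)nc2n1` differs from compound 3 by 4-chlorophenyl in place of 2-bromophenyl on a saturated chain carbon bound to a sulfur. Of the measured steps, an at least 3.5-fold higher number from compound 1 to compound 3 (0.55 log units; beyond the scatter) bears on this position, while a step that the two limits leave unreadable from compound 2 to compound 3. Among the measured compounds shown here, no measured step exchanges one substituted phenyl group for another on this carbon. Compound 4 is therefore expected to stay at or near the limit, with an estimated 100000 nM, between 30000 nM and 300000 nM. The expected step is a number no higher from compound 3 to compound 4 (the limit leaves the size open), nothing beyond the scatter.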

Compound 4, half-maximal inhibitory concentration: > 100000 nM
Compound 4: a limit, no number; the forecaster's own chance of this, stated with the estimate: 70%; the middle value lies on the limit itself.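

With 4-chlorophenyl on the saturated chain carbon bound to a sulfur, a second substituted phenyl group joins 2-bromophenyl at the limit in this assay, and the comparison with cyclopropyl shows an at least 3.5-fold higher number from compound 1 to compound 4 (0.55 log units; beyond the scatter). The steps from compound 2 and from compound 3 to compound 4 cannot be read, as both ends of each are limits. Among the compounds shown, only compound 1 gives a number: the limit of > 100000 nM in this assay, at which 3 of the 4 values shown sit.

No order among compound 2, compound 3 and compound 4 can be given. On these data alone, whether an amine or a carboxylic acid on the phenyl ring, or a longer chain on this carbon, would give a number stays open.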